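Solubility when the methylpiperazine is taken away

The source may report more compounds than this note shows. Statements on the series, on what has been measured and on what is new or still open speak of the compounds shown alone.

Measured compounds:
compound 1 `C=CC(=O)N1CC[C@H](N2C(=O)N(C3CCCCC3)Cc3cnc(Nc4ccc(N5CCN(C)CC5)cc4OC)nc32)C1`: 763 ug/mL
compound 2 `C=CC(=O)N1CC[C@H](N2C(=O)N(c3ccccc3)Cc3cnc(Nc4cccc(N5CCN(C)CC5)c4)nc32)C1`: 714 ug/mL

In a physicochemical assay for solubility, read by HPLC, in phosphate buffer, measured as thermodynamic solubility, with a stated time of 24 h, at pH 6.8 (a lower number here means a less soluble compound, a higher number a more soluble compound), compound 2 gives 714 ug/mL, the smaller of the two numbers, while compound 1 gives 763 ug/mL, a gap that lies within the usual scatter. Compound 3 `C=CC(=O)N1CC[C@H](N2C(=O)N(c3ccccc3)Cc3cnc(Nc4ccccc4)nc32)C1` differs from compound 2 in one place: hydrogen in place of 4-methylpiperazin-1-yl on an aromatic carbon. Among the compounds with values here, no measured pair covers this change, so the step rests on the structural change alone. A clear drop, well beyond the scatter, is expected, as a 24-fold lower number from compound 2 to compound 3 (1.38 log units; beyond the scatter) states. Compound 3 is therefore estimated at 30 ug/mL, with a range from 5 ug/mL to 150 ug/mL.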

Compound 3, solubility: 3.5 ug/mL
For compound 3 the middle estimate is 8.6-fold (0.93 log units) above the measured one, and the stated range ends above it.
By their numbers in this assay, from the lowest: compound 3; then compounds 2 and 1 (each within the scatter of the next).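

In this assay, within the data shown here, the replacement of 4-methylpiperazin-1-yl by hydrogen on this aromatic carbon gives a 200-fold lower number from compound 2 to compound 3 (2.31 log units; beyond the scatter), the first comparison here of compounds differing in one place. The step is large and lies beyond the scatter, so the read-out is strongly sensitive to this one change on this scaffold. Nothing in the data shown bears on the reason for it.

From the compounds shown here alone, whether a morpholine, a dimethylamino group or a carboxylic acid on that carbon would restore a number close to that of compound 2 stays open. So does whether the same replacement would give a step of like size in compound 1.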